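From a six-membered ring to a methylated five-membered one

A few compounds are considered here, and "the series" means these few. Any claim that something is new, unique, unknown or untested is made for them only; others in the source may bear on it.

In a physicochemical assay for lipophilicity (a higher number here means a more lipophilic compound, a lower number a more polar compound), compound 1 (`COc1cccc(S(=O)(=O)N(Cc2ccc(F)cc2)C[C@@H]2CCC(=O)N2)c1`) gives 3.1, compound 2 (`N#Cc1cccc(S(=O)(=O)N(Cc2ccc(F)cc2)C[C@@H]2CCC(=O)N2)c1`) gives 2.7 and compound 3 (`N#Cc1cccc(S(=O)(=O)N(Cc2ccc(F)cc2)C[C@@H]2CCCC(=O)N2)c1`) gives 2.9, so compound 3 lies within the scatter of both others. Compound 4 (`CN1C(=O)CC[C@H]1CN(Cc1ccc(F)cc1)S(=O)(=O)c1cccc(C#N)c1`) has the same atoms as compound 3, joined differently: 1-methyl-5-oxopyrrolidin-2-yl in place of 6-oxopiperidin-2-yl, (1-methyl-5-oxopyrrolidin-2-yl in place of 6-oxopiperidin-2-yl on a saturated chain carbon bound to a sulfonamide nitrogen). The step of a number 0.40 log units lower from compound 1 to compound 2 (beyond the scatter) concerns an aromatic carbon, so it says little here. The step of a number 0.20 log units higher from compound 2 to compound 3 (within the scatter) changes this same place and stays small. Going by the values given here, no measured compound carries the methyl group, so that part remains open. A change within the scatter is expected in this assay, namely a number 0.10 log units higher from compound 3 to compound 4 (within the scatter). For compound 4 the estimate is 3, with an expected range of 2.6 to 3.3.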

Compound 4, distribution coefficient: 3.1
Compound 4: the middle estimate sits 0.10 log units below what was measured; low and high end bracket the measured number.
By their numbers in this assay, from the lowest: compounds 2, 3, 1 and 4 (each within the scatter of the next, the first and the last beyond it).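

In this assay, going by these compounds alone, putting methyl in place of hydrogen on the amide-type ring nitrogen gives a number 0.40 log units higher from compound 2 to compound 4 (beyond the scatter) and is the first change at this position to lie beyond the scatter. Moving from 6-oxopiperidin-2-yl to 1-methyl-5-oxopyrrolidin-2-yl, with the same atoms joined differently, gives a number 0.20 log units higher from compound 3 to compound 4 (within the scatter) and stays within it. Nothing available here accounts for the size of either step. Open, on these data alone, is whether an ethyl group or a longer chain on that ring nitrogen would go further than methyl. Also open, as far as these compounds go, is how a methyl group on the nitrogen of the 6-oxopiperidin-2-yl ring would read.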